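This account rests on a few compounds, and the source may have more. Where it says the series, first, only, none or still open, it means among the compounds named here.

Measured so far in a physicochemical assay for solubility, read by HPLC, in simulated intestinal fluid, with a stated time of 16 h, at pH 6.5, tested at 2.5 mg/mL; on this read-out lower numbers stand for lower solubility and higher numbers for higher solubility:
- compound 1 `CNC(=O)c1cc(C(=O)N[C@H]2[C@@H]3C[C@H](O)C[C@@H]32)cc2c1OC[C@@]2(C)c1ccccc1`: 539 ug/mL
- compound 2 `CNC(=O)c1cc(C(=O)N[C@H]2C[C@@H]2C)cc2c1OC[C@@]2(C)c1ccccc1`: 88 ug/mL

Compound 2 holds the lower of these two numbers. Compound 3 `CNC(=O)c1cc(C(=O)N[C@H]2C[C@@H]2C)cc2c1OC[C@@]2(CO)c1ccccc1` differs from it in one place, methyl to hydroxymethyl: hydroxy in place of hydrogen on a saturated chain carbon bound to a saturated ring carbon. This puts hydroxy in place of hydrogen on a saturated chain carbon bound to a saturated ring carbon.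

For the measured compounds named here, no measured step makes this exact change. The only one that bears on it, and only loosely, is a 6.1-fold lower number from compound 1 to compound 2 (0.79 log units; beyond the scatter). That step exchanges a whole group on an amide-type nitrogen, and the group in compound 1 contains an oxygen. Read in reverse, it suggests a rise, so a smaller upward step is expected in this assay, possibly none beyond the scatter. The expected step is a 2.2-fold higher number from compound 2 to compound 3 (0.33 log units; beyond the scatter). For compound 3 the estimated value is 190 ug/mL, with an expected range from 85 ug/mL to 480 ug/mL.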

Compound 3, solubility: > 1000 ug/mL
Compound 3: a limit, no number (the forecaster's own chance of this, stated with the estimate: 2%); middle value at least 5.2-fold (0.72 log units) from the limit.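

In this assay, hydroxy in place of hydrogen on a saturated chain carbon bound to a saturated ring carbon gives an at least 11-fold higher number from compound 2 to compound 3 (1.05 log units; beyond the scatter), a large step from one small change. Compound 3 gives > 1000 ug/mL, which is a limit of the assay and not a number. The earlier compounds shown here differed only in the group on an amide-type nitrogen, whereas this pair shows that the read-out also moves strongly at this second position, with that group held constant.

As far as these compounds go, the full size of the step cannot be read, because the value for compound 3 is a limit: the limit of > 1000 ug/mL in this assay, at which 1 of the 3 values shown sits. Also open is whether a methoxy, an amine, a carboxylic acid or a longer chain bearing hydroxy at this position would give a similar step.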